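The source may hold more compounds than are shown below. What is called first, only, known or untested is meant among the compounds shown, and "the series" means these compounds.

Compound 3 `Cc1ccccc1C(=O)NC(CCN(C)C)c1ccc(Cl)cc1`: 175%
Compound 1 `Cc1ccsc1C(=O)OC(CCN(C)C)c1ccc(Cl)cc1`: 119%
Compound 2 `Cc1c(Cl)cccc1C(=O)OC(CCN(C)C)c1ccc(Cl)cc1`: 118%

In an assay on NIH3T3 cells with Urotensin-2 receptor (Homo sapiens) as the target (on this read-out lower numbers stand for smaller maximal responses and higher numbers for larger maximal responses), compound 3 stands highest of the three numbers, well beyond the scatter above compound 1 and compound 2, while the step of a number 1 percentage points lower from compound 1 to compound 2 (within the scatter) stays within the scatter. Compound 4 `Cc1cccc(Cl)c1C(=O)NC(CCN(C)C)c1ccc(Cl)cc1` differs from compound 3 by chloro in place of hydrogen on an aromatic carbon, taking 2-methylphenyl to 2-chloro-6-methylphenyl. Going by the values given here, the only measured step that bears on this, a number 1 percentage points lower from compound 1 to compound 2 (within the scatter), also changed the aryl group on the carbonyl carbon to one bearing a chloro and left the maximal response essentially unchanged. The step of a number 7 percentage points lower from compound 3 to compound 4 (within the scatter) is therefore expected to be small, with no direction beyond the scatter. Compound 4 is estimated at 168%, within a range from 130% to 205%.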

Compound 4, largest response reached (reported as efficacy), in percent of the reference or control that the assay uses: 105%
Beside the measured number, compound 4's estimate is 63 percentage points above it; the measured number lies below the stated range.
By their numbers in this assay, from the lowest: compound 4; then compounds 2 and 1 (each within the scatter of the next); then compound 3.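

In this assay, a single chloro in place of hydrogen on an aromatic carbon, taking 2-methylphenyl to 2-chloro-6-methylphenyl, gives a number 70 percentage points lower from compound 3 to compound 4 (beyond the scatter), so this position is far from indifferent to substitution. The earlier aryl exchange, a number 1 percentage points lower from compound 1 to compound 2 (within the scatter), gave no sign of a change of this size. Nothing available accounts for the drop. The compounds shown leave open whether a fluoro, methoxy or second methyl group at this position would lower the maximal response as far. They also leave open whether the same chloro would act alike with the methyl group replaced by hydrogen.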